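Phenyl for benzyl on the chain carbon: cytotoxicity notes

The source may hold more compounds than are shown below. What is called first, only, known or untested is meant among the compounds shown, and "the series" means these compounds.

Compound 1 `O=C1N(CCC(CCOc2ccc(-c3ccc(Cl)cc3)cc2)Cc2ccccc2)CCN1c1ccncc1` is the reference point for this step. In an ADME assay on cells (Homo sapiens) for cytotoxicity (on this read-out higher numbers stand for lower toxicity in this test and lower numbers for higher toxicity in this test), compound 1 returns only a limit, > 10000 nM. Compound 2 `O=C1N(Cc2ccccc2COc2ccc(-c3ccc(Cl)cc3)cc2)CCN1c1ccncc1` likewise returns only a limit in this assay, > 1250 nM. Compound 3 `CC(CCCN1CCN(c2ccncc2)C1=O)COc1ccc(-c2ccc(Cl)cc2)cc1` also returns only a limit in this assay, > 25000 nM. Going by the values given here, all three values are limits and none is a measured number, so no step between measured compounds can be drawn. Compound 4 `O=C1N(CCC(CCOc2ccc(-c3ccc(Cl)cc3)cc2)c2ccccc2)CCN1c1ccncc1` is not yet measured. It differs from compound 1 by phenyl in place of benzyl on a saturated chain carbon bound to two saturated chain carbons. Among the compounds with values here, with no measured step to lean on, the expectation is no change beyond the scatter for a step that the limit leaves unreadable from compound 1 to compound 4, and a limit is expected again. The estimate for compound 4 in this assay is 15000 nM, within 5000 nM to 50000 nM.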

Compound 4, half-maximal cytotoxic concentration: > 25000 nM
Compound 4 was reported as a limit; the forecaster's own chance of this, stated with the estimate: 80%; middle value at least 1.6-fold (0.22 log units) away from the limit.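

Compound 1 and compound 4 both return only limits in this assay, so the change from benzyl to phenyl gives no readable step. The compounds shown leave open at what concentration any of them turns cytotoxic.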